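Dropping the Bromo Group from Compound 2

The compounds below may be only part of what the source reports. "The series", "measured", "known", "first", "only" and "open" are said of these compounds alone.

Compound 2, `COC(=O)c1cc(Br)ccc1OC(=O)COc1cc(O)c2c(=O)cc(-c3ccccc3)oc2c1`, was tested in an ADME assay on cells (T-cell, Mus musculus, strain BALB/c) for cytotoxicity, read by MTT assay, with a stated time of 48 h; a lower number here means that less compound is tolerated, a higher number that more compound is tolerated. In this setting compound 2 reaches only a limit of the measurement, > 450000 nM, so its true value is not known. The same holds for compound 1, `COC(=O)c1cc(Cl)ccc1OC(=O)COc1cc(O)c2c(=O)cc(-c3ccccc3)oc2c1`, which in this assay also stops at a limit, > 436000 nM. For the measured compounds named here, the single measured step, a step that the two limits leave unreadable from compound 1 to compound 2, therefore cannot be read, as the limit of > 436000 nM in this assay, at which 1 of the 2 values shown sits, and the limit of > 450000 nM in this assay, at which 1 of the 2 values shown sits, show. Compound 3, `COC(=O)c1ccccc1OC(=O)COc1cc(O)c2c(=O)cc(-c3ccccc3)oc2c1`, is the next member: hydrogen in place of bromo on an aromatic carbon. Going by the values given here, no measured step speaks to this change, and nothing beyond the two limits is available, so no step beyond the scatter is expected in this assay in either direction. Compound 3 is expected to give 450000 nM, between 200000 nM and 1000000 nM, most likely again as a limit rather than a number. The expected step of a number no higher from compound 2 to compound 3 (the limit leaves the size open) is thus close to none.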

Compound 3, half-maximal cytotoxic concentration: 265000 nM
Compound 3: the middle estimate sits 1.7-fold (0.23 log units) above what was measured; measured number inside the range.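

With hydrogen on this aromatic carbon, the series gives its first true number: in this assay compound 3 gives 265000 nM. The two halogen-bearing compounds, compound 1 and compound 2, stop at limits of the assay. Losing the bromo group gives an at least 1.6-fold lower number from compound 2 to compound 3 (0.22 log units; that floor lies within the scatter), and losing the chloro group gives an at least 1.6-fold lower number from compound 1 to compound 3 (0.21 log units; that floor lies within the scatter). Both figures are only floors, so the halogen at this place may matter more than they show, but the real size of either step cannot be read.

From the compounds shown here alone, the step between compound 1 and compound 2 also cannot be read, so it stays open whether the two halogens differ from each other in this assay. Going by these compounds, it is equally open how a methoxy group, an amine or a nitrile at this same place would compare with hydrogen or the halogens.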